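The source may report more compounds than this note shows. Statements on the series, on what has been measured and on what is new or still open speak of the compounds shown alone.

Of the compounds shown here, two have been measured so far in a functional assay on PC-12 cells (Rattus norvegicus) for cytotoxicity, read by MTT assay, with stated times of 3 h and 2 h, tested at 1 uM; on this read-out lower numbers stand for a weaker effect and higher numbers for a stronger effect at the one concentration tested. Compound 1, `CCOC(=O)c1cc2ccc(OCCCCCn3cc(CNC(=O)CCCCC4CCSS4)nn3)cc2oc1=O`, gives 35.1%. Compound 2, `O=C(CCCCC1CCSS1)NCc1cn(CCCCCOc2ccc3cc(-c4ccccc4)c(=O)oc3c2)nn1`, gives 30.7%, and the step of a number 4.4 percentage points lower from compound 1 to compound 2 (within the scatter), so compound 2 stands at the lower of the two numbers, but within the scatter of compound 1, so that neither can be called the stronger one.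

The next compound, compound 3, is `COc1ccc(-c2cc3ccc(OCCCCCn4cc(CNC(=O)CCCCC5CCSS5)nn4)cc3oc2=O)cc1OC`. The change from compound 2 is 3,4-dimethoxyphenyl in place of phenyl on an aromatic carbon. Among the measured compounds shown here, the only measured step that touches this position of the shared core is the one from compound 1 to compound 2, which swapped one group for another at the same aromatic carbon and stayed within the scatter. That is thin ground, but it gives no sign that this position drives the read-out, so the step from compound 2 to compound 3 is expected to be a number 0.3 percentage points higher from compound 2 to compound 3 (within the scatter), which is none beyond the scatter. Compound 3 is therefore estimated to give 31%, with a range of 21% to 41%.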

Compound 3, a percentage reported as activity, at one concentration (the size of the read-out at that concentration, not a potency): 42.2%
For compound 3 the middle estimate is 11.2 percentage points below the measured one, outside the stated range (above it).
By their numbers in this assay, from the lowest: compounds 2, 1 and 3 (each within the scatter of the next, the first and the last beyond it).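

Among the compounds shown here, this position can move the read-out after all: in this assay, 3,4-dimethoxyphenyl in place of phenyl gives a number 11.5 percentage points higher from compound 2 to compound 3 (beyond the scatter) as the only step so far to pass beyond the scatter, whereas the earlier swap gave only a number 4.4 percentage points lower from compound 1 to compound 2 (within the scatter) at the same aromatic carbon. The change is not clear-cut against every neighbour, since setting the same group in place of ethoxycarbonyl gives a number 7.1 percentage points higher from compound 1 to compound 3 (within the scatter) and so leaves compound 3 and compound 1 unseparated, which means the clear difference holds only against the plain phenyl of compound 2. No measurement shown here accounts for the difference that the two methoxy groups make.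

The compounds shown leave open whether both methoxy groups are needed or a phenyl carrying a single methoxy group would give the same step. They also leave open what a phenyl carrying an amine or a carboxylic acid would do at this aromatic carbon, and so how far this read-out can be moved from this position.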